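Replacing the 1H-indol-6-yl group of compound 2

This account rests on a few compounds, and the source may have more. Where it says the series, first, only, none or still open, it means among the compounds named here.

Among the measured compounds shown here, in a functional assay on K562 cells (Homo sapiens) for inhibition, read by trypan blue exclusion, with a stated time of 72 h (a higher number here means a weaker inhibitor, a lower number a stronger inhibitor), compound 2 `Cn1c(=O)c(S(=O)(=O)c2ccc(F)cc2F)cc2cnc(Nc3ccc4cc[nH]c4c3)nc21` gives 5000 nM, the lower of the two numbers measured so far, while compound 1 `Cn1c(=O)c(S(=O)(=O)c2ccc(F)cc2F)cc2cnc(Nc3ccc4c(c3)CC(=O)N4)nc21` gives 15000 nM. Compound 3 `Cn1c(=O)c(S(=O)(=O)c2ccc(F)cc2F)cc2cnc(Nc3ccc4c(c3)C(=O)C(=O)N4)nc21` changes the group on the nitrogen: a group of 11 heavy atoms (8 carbon, 1 nitrogen, 2 oxygen; one five-membered non-aromatic ring with 1 hetero atom, one six-membered aromatic ring of carbon only) in place of a group of 9 heavy atoms (8 carbon, 1 nitrogen; one five-membered aromatic ring with 1 hetero atom, one six-membered aromatic ring of carbon only), on a nitrogen on an aromatic ring. For the measured compounds named here, one measured step bears on this, a 3.0-fold lower number from compound 1 to compound 2 (0.48 log units; beyond the scatter), in which a five-membered non-aromatic ring also gave way to a five-membered aromatic ring. Compound 3 reverses that kind of change, so a modest rise of similar size is expected. The expected step is a 2.6-fold higher number from compound 2 to compound 3 (0.41 log units; beyond the scatter). Compound 3 is estimated at 13000 nM, within a range of 5000 nM to 40000 nM.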

Compound 3, half-maximal inhibitory concentration: 30000 nM
Beside the measured number, compound 3's estimate is 2.3-fold (0.36 log units) below it; low and high end bracket the measured number.
By their numbers in this assay, from the lowest: compound 2; then compounds 1 and 3 (each within the scatter of the next).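

In this assay, the new group on this nitrogen gives a 6.0-fold higher number from compound 2 to compound 3 (0.78 log units; beyond the scatter) and so widens the gap that the 1H-indol-6-yl group holds over the non-aromatic ring groups. A further carbonyl on the non-aromatic five-membered ring gives a 2.0-fold higher number from compound 1 to compound 3 (0.30 log units; within the scatter) and so leaves compounds 1 and 3 together, both apart from compound 2. No measurement shown here accounts for these differences.

Still open, from the compounds shown here alone, is whether any group on this nitrogen reaches a much lower number. A phenyl ring carrying an amine or a carboxylic acid might show this.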